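The source may hold more compounds than are shown below. What is called first, only, known or untested is meant among the compounds shown, and "the series" means these compounds.

Compound 1 `FC(F)(F)c1cccc(-c2nc3cnc(Nc4ncccn4)cc3[nH]2)c1`: < 5000 nM
Compound 2 `Fc1ccc(-c2nc3cnc(Nc4ccccn4)cc3[nH]2)cc1C(F)(F)F`: < 5000 nM

Both compounds were tested in a physicochemical assay for solubility, using the shake flask method, in phosphate buffer, measured as kinetic solubility, with a stated time of 20 h, at pH 6.5; a higher number here means a more soluble compound, a lower number a less soluble compound. Compound 1 gives < 5000 nM, which is a limit of the assay and not an exact number. Compound 2 also gives a limit, < 5000 nM. The picture so far is therefore (the limit of < 5000 nM in this assay, at which 2 of the 2 values shown sit).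

Compound 3 `FC(F)(F)c1ccc(Nc2cc3[nH]c(-c4cccc(C(F)(F)F)c4)nc3cn2)nc1` keeps the core of compound 1 and changes one group: 5-(trifluoromethyl)pyridin-2-yl in place of pyrimidin-2-yl on a nitrogen on an aromatic ring. Among the compounds with values here, no measured pair shows what this swap does, so any expectation is tentative. A modest downward move is expected in this assay. The estimated change is a step that the limit leaves unreadable from compound 1 to compound 3. Another limit instead of an exact number is quite likely. For compound 3 the expected value is 2500 nM, with an estimated range from 600 nM to 5000 nM.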

Compound 3, solubility: < 5000 nM
Compound 3: no number, only a limit; the forecaster's own chance of this, stated with the estimate: 85%; the middle value lies beyond the limit too.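

No step from compound 1 to compound 3 can be read in this assay, because each compound gives only a limit and not an exact number: the limit of < 5000 nM in this assay, at which 3 of the 3 values shown sit.

Going by these compounds, what remains open is the exact value of compound 1, compound 2 and compound 3, and how far 5-(trifluoromethyl)pyridin-2-yl in place of pyrimidin-2-yl moves the result.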